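The source may hold more compounds than are shown below. What is called first, only, known or untested is meant among the compounds shown, and "the series" means these compounds.

Measured compounds:
- compound 1, `COc1ccc(C(=O)Nc2cccc(-c3oc4cc(-c5ccc(F)cc5)ccc4c(=O)c3O)c2)cc1`: 8700 nM
- compound 2, `CCc1ccc(C(=O)Nc2cccc(-c3oc4cc(-c5ccc(F)cc5)ccc4c(=O)c3O)c2)cc1`: 18500 nM
- compound 3, `O=C(Nc1cccc(-c2oc3cc(-c4ccc(F)cc4)ccc3c(=O)c2O)c1)c1ccc(Cl)nc1`: 3580 nM

All three share one core and differ only in the aryl group on the amide carbonyl. In a functional assay on A549 cells (Homo sapiens) for antiproliferative activity, read by CCK-8 assay, with a stated time of 72 h (on this read-out higher numbers stand for weaker inhibition and lower numbers for stronger inhibition), compound 3 gives the lowest number of the three, beyond the scatter from both others; the nearest is compound 1, the furthest compound 2.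

Compound 4 is `CCCc1ccc(C(=O)Nc2cccc(-c3oc4cc(-c5ccc(F)cc5)ccc4c(=O)c3O)c2)cc1`. The change from compound 3 is 4-propylphenyl in place of 6-chloropyridin-3-yl on a carbonyl carbon. Among the compounds with values here, two measured steps bear on it directly. The step of a 5.2-fold lower number from compound 2 to compound 3 (0.71 log units; beyond the scatter) is the closest analogue, since a 4-alkylphenyl gives way to the 6-chloropyridin-3-yl group; read backwards it says that going from compound 3 to a 4-alkylphenyl amide raises the number by about that much. The step of a 2.4-fold lower number from compound 1 to compound 3 (0.39 log units; beyond the scatter) points the same way but is smaller. The step of a 2.1-fold higher number from compound 1 to compound 2 (0.33 log units; beyond the scatter) shows that the 4-ethylphenyl amide sits higher than the 4-methoxyphenyl amide. Within the data shown here, no measured pair tells how propyl compares with ethyl, so that part of the change is unknown.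

Taken together, a rise in this assay beyond the scatter is expected for compound 4, on the order of a 5.0-fold higher number from compound 3 to compound 4 (0.70 log units; beyond the scatter). Compound 4 is therefore estimated at 18000 nM, with a range from 7000 nM to 50000 nM.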

Compound 4, half-maximal inhibitory concentration: 47600 nM
Estimate against measurement, compound 4: 2.6-fold (0.42 log units) below; the measured number falls inside the stated range.
By their numbers in this assay, from the lowest: compound 3; then compound 1; then compound 2; then compound 4.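

In this assay, adding one methyl to the chain gives a 2.6-fold higher number from compound 2 to compound 4 (0.41 log units; beyond the scatter), which fills the gap between ethyl and propyl: among these two 4-alkylphenyl amides, the longer chain gives the higher number. Compound 4 now has the highest number of the series, with a 5.5-fold higher number from compound 1 to compound 4 (0.74 log units; beyond the scatter) and a 13-fold higher number from compound 3 to compound 4 (1.12 log units; beyond the scatter), the latter being the largest step at this carbonyl position and the only one rated large. Nothing on hand gives a cause for these steps.

Within the data shown here, two 4-alkylphenyl amides define only one chain-length step, so a 4-methylphenyl or 4-butylphenyl amide would be needed to show whether the number changes steadily with chain length. The 6-chloropyridin-3-yl group also differs from the other aryl groups in both its ring nitrogen and its chlorine, so 4-chlorophenyl and pyridin-3-yl amides would be needed to separate those two features.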